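The source may report more compounds than this note shows. Statements on the series, on what has been measured and on what is new or still open speak of the compounds shown alone.

Compound 1 `CN1CC[C@H](c2c(O)cc(O)c3c(=O)cc(/C=C/c4cccc(Cl)c4)oc23)[C@H](O)C1`: 82%
Compound 2 `CN1CC[C@H](c2c(O)cc(O)c3c(=O)cc(/C=C/c4cccc(F)c4)oc23)[C@H](O)C1`: 83%

In a functional assay on MCF7 cells (Homo sapiens) for inhibition, read by MTT assay, with a stated time of 48 h, tested at 10 uM (on this read-out higher numbers stand for more inhibition of growth at the one concentration tested and lower numbers for less inhibition of growth), compound 2 gives 83%, level with compound 1 within the scatter. Compound 3 `CN1CC[C@H](c2c(O)cc(O)c3c(=O)cc(/C=C/c4ccccc4F)oc23)[C@H](O)C1` has the same atoms as compound 2, joined differently: 2-fluorophenyl in place of 3-fluorophenyl on a double-bonded chain carbon bound to a double-bonded chain carbon. Within the data shown here, the fluoro group thus changes place, while the only measured step, a number 1 percentage points higher from compound 1 to compound 2 (within the scatter), exchanges one halogen for another and stays within the scatter. Among the measured compounds shown here, that step bears only indirectly, and no measured pair tests this move. No shift beyond the scatter is therefore expected, and the estimated change is a number 3 percentage points lower from compound 2 to compound 3 (within the scatter). Compound 3 is expected to give 80%, with an estimated range of 66% to 91%.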

Compound 3, percent growth inhibition at one concentration: 62%
The estimate for compound 3 lay 18 percentage points above the measured number; measured number outside the range, below it.
By their numbers in this assay, from the lowest: compound 3; then compounds 1 and 2 (each within the scatter of the next).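

In this assay, the place of the halogen on the phenyl group matters where the exchange of one halogen for another did not: 2-fluorophenyl in place of 3-fluorophenyl gives a number 21 percentage points lower from compound 2 to compound 3 (beyond the scatter), and 2-fluorophenyl in place of 3-chlorophenyl gives a number 20 percentage points lower from compound 1 to compound 3 (beyond the scatter). Among these compounds, these are the first steps beyond the scatter, so this position on the chain's phenyl group is sensitive to where the halogen sits. Nothing available explains the drop. From the compounds shown here alone, whether 2-chlorophenyl would read like 2-fluorophenyl remains open, as does how a methoxy or an amino group would read on the same phenyl group.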